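The source may hold more compounds than are shown below. What is called first, only, known or untested is meant among the compounds shown, and "the series" means these compounds.

In an ADME assay on NIH3T3 cells (Mus musculus) for cytotoxicity, read by MTT assay, with a stated time of 24 h (on this read-out higher numbers stand for weaker inhibition and lower numbers for stronger inhibition), compound 1 `COc1ccc(-c2nnc(N3CCN(C(=O)CN4CCN(c5ccccc5Cl)CC4)CC3)nc2-c2ccc(OC)cc2)cc1` gives > 814000 nM, which is a limit of the assay rather than a number. Compound 2 `COc1ccc(-c2nnc(N3CCN(C(=O)CN4CCN(c5cccc(OC)c5)CC4)CC3)nc2-c2ccc(OC)cc2)cc1` gives > 821000 nM in this assay, again a limit. The change between these two, (3-methoxyphenyl in place of 2-chlorophenyl on an amine nitrogen in a ring), makes a step that the two limits leave unreadable from compound 1 to compound 2. Compound 3 `O=C(CN1CCN(c2ccccc2Cl)CC1)N1CCN(c2nnc(-c3ccc(Cl)cc3)c(-c3ccc(Cl)cc3)n2)CC1` gives > 803000 nM in this assay, also a limit. How the core of compound 3 differs from the core of compound 1 is not broken down here. Compound 4 `COc1cccc(N2CCN(CC(=O)N3CCN(c4nnc(-c5ccc(Cl)cc5)c(-c5ccc(Cl)cc5)n4)CC3)CC2)c1` is not yet measured in this assay; it differs from compound 3 by 3-methoxyphenyl in place of 2-chlorophenyl on an amine nitrogen in a ring, the same change as from compound 1 to compound 2. Because the three measured values sit at the limit of > 803000 nM in this assay, at which 1 of the 3 values shown sits, the limit of > 814000 nM in this assay, at which 1 of the 3 values shown sits, and (the limit of > 821000 nM in this assay, at which 1 of the 3 values shown sits), the expected step is a step that the limit leaves unreadable from compound 3 to compound 4. Compound 4 is therefore estimated at 900000 nM in this assay, most likely again only a limit.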

Compound 4, half-maximal inhibitory concentration: 202000 nM
Compound 4: middle estimate off by 4.5-fold (0.65 log units), on the high side; measured number outside the range, below it.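

In this assay, putting 3-methoxyphenyl in place of 2-chlorophenyl on an amine nitrogen in a ring gives an at least 3.9-fold lower number from compound 3 to compound 4 (0.59 log units; beyond the scatter), so on this core the change brings clearly stronger inhibition, and the true size may be larger, as compound 3 has only a limit. On the core of compound 1, compound 1 gives > 814000 nM, which is a limit and not a number. Compound 2 gives > 821000 nM, also a limit, so the same change cannot be read there, and whether the step carries from one core to the other stays unshown.

The compounds shown leave open whether the lower number follows from the methoxy group arriving or the chlorine leaving. A plain phenyl group at that place would help to separate the two.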